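Cyclopropyl on the Ring Amide Nitrogen of a Weak Antiproliferative

This account rests on a few compounds, and the source may have more. Where it says the series, first, only, none or still open, it means among the compounds named here.

Compound 1 `COc1ncc(-c2ccc3c(c2)N(c2ccc(Cl)cc2)C(=O)CO3)cc1NS(=O)(=O)c1ccc(F)cc1` gives 24100 nM in a functional assay on A-375 cells (Homo sapiens) for antiproliferative activity, read by MTT assay, with a stated time of 72 h; on this read-out higher numbers stand for weaker inhibition and lower numbers for stronger inhibition.
Compound 2 `COc1ncc(-c2ccc3c(c2)NC(=O)CO3)cc1NS(=O)(=O)c1ccc(F)cc1` gives 26300 nM in this assay.

Of the two measured compounds, compound 2 has the highest number, yet it is barely apart from compound 1: the step of a 1.1-fold higher number from compound 1 to compound 2 (0.04 log units; within the scatter) lies within the scatter, so the two cannot be ranked against each other.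

Compound 3 `COc1ncc(-c2ccc3c(c2)N(C2CC2)C(=O)CO3)cc1NS(=O)(=O)c1ccc(F)cc1` has not yet been measured. It differs from compound 2 in one place: cyclopropyl in place of hydrogen on an amide-type nitrogen in a ring

Within the data shown here, the only measured step that speaks to this position is the one from compound 1 to compound 2, in which a 4-chlorophenyl gave way to hydrogen on the same amide-type nitrogen in a ring, and the number hardly moved, as a 1.1-fold higher number from compound 1 to compound 2 (0.04 log units; within the scatter) shows. Swapping the hydrogen for cyclopropyl touches the same nitrogen, so no step beyond the scatter is expected in this assay in either direction.

For compound 3 the estimate is therefore 24000 nM, with a range from 10000 nM to 60000 nM, which corresponds to an expected step of a 1.1-fold lower number from compound 2 to compound 3 (0.04 log units; within the scatter).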

Compound 3, half-maximal inhibitory concentration: 23900 nM
Estimate against measurement, compound 3: 1.0-fold (0.00 log units) above, and the stated range covers the measured number.
By their numbers in this assay, from the lowest: compounds 3, 1 and 2 (each within the scatter of the next).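

In this assay, cyclopropyl in place of hydrogen on the amide-type nitrogen in a ring gives a 1.1-fold lower number from compound 2 to compound 3 (0.04 log units; within the scatter), and cyclopropyl in place of 4-chlorophenyl gives a 1.0-fold lower number from compound 1 to compound 3 (0.00 log units; within the scatter). Among these compounds, the earlier compounds offered only one step at this nitrogen, whereas three different groups can now be compared there: hydrogen, cyclopropyl and 4-chlorophenyl, all within the scatter of one another, so this read-out does not tell them apart. No supporting measurement is available to explain this lack of separation.

The three compounds leave open whether this nitrogen is insensitive to every kind of group, since all those shown are either hydrogen or carbon-based groups without an amine or a carboxylic acid. An amine or carboxylic acid placed at the end of a longer chain on this nitrogen would test whether the number can move beyond the scatter at this position, and changes elsewhere on the shared core remain a separate question.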